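The compounds below may be only part of what the source reports. "The series", "measured", "known", "first", "only" and "open" are said of these compounds alone.

Of the compounds shown here, two have been measured in a functional assay on MIA PaCa-2 cells (Homo sapiens) for inhibition, read by MTT assay, with a stated time of 7 days (a higher number here means a weaker inhibitor, a lower number a stronger inhibitor), so far. Compound 1 `CCN(CC)S(=O)(=O)c1ccc(S(=O)(=O)N2CCC[C@@H](C(=O)N[C@H]3CC[C@H](OC)CC3)C2)cc1` gives 1350 nM and stands at the highest of the two numbers, so it is the weaker inhibitor of the pair. Compound 2 `O=C([C@@H]1CCCN(S(=O)(=O)c2ccc(S(=O)(=O)C3CC3)cc2)C1)N1CCC(F)(F)CC1` gives 26 nM, a far lower number that lies well beyond the usual scatter of this assay, so compound 2 is clearly the stronger inhibitor of the two.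

Compound 3 `CCN(CC)S(=O)(=O)c1ccc(S(=O)(=O)N2CCC[C@@H](C(=O)N3CCC(C(F)(F)F)CC3)C2)cc1` has not yet been measured. It differs from compound 1 in one place: 4-(trifluoromethyl)piperidin-1-yl in place of (4-methoxycyclohexyl)amino on a carbonyl carbon. The change removes the amide hydrogen and the methoxy group of compound 1 and brings in a trifluoromethyl group on a ring containing one nitrogen.

Among the compounds with values here, no step between measured compounds matches this change, so the expectation rests on the two values alone. Compound 3 is expected to give a lower number than compound 1 in this assay, with a step of a 9.0-fold lower number from compound 1 to compound 3 (0.95 log units; beyond the scatter) that goes beyond the scatter. For compound 3 the estimate is 150 nM, within a range from 35 nM to 650 nM.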

Compound 3, half-maximal inhibitory concentration: 320 nM
Beside the measured number, compound 3's estimate is 2.1-fold (0.33 log units) below it, and the stated range covers the measured number.
By their numbers in this assay, from the lowest: compound 2; then compound 3; then compound 1.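

In this assay the group on the carbonyl carbon can be exchanged without losing the effect: 4-(trifluoromethyl)piperidin-1-yl in place of (4-methoxycyclohexyl)amino gives a 4.2-fold lower number from compound 1 to compound 3 (0.63 log units; beyond the scatter) in a modest step. Within the data shown here, this is the first reading at this place, and it shows that the number responds to the group there, even with the amide hydrogen and the methoxy group both gone. The exchange alters all of these together with the ring and the trifluoromethyl group, and nothing measured here says why the number falls.

Still open, going by these compounds, is which part of the exchange matters: the lost amide hydrogen, the piperidine ring itself or the trifluoromethyl group. An unsubstituted piperidine or a morpholine on the same carbonyl carbon would help to separate these parts.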